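Replacing the large amide substituent of compound 2

This account rests on a few compounds, and the source may have more. Where it says the series, first, only, none or still open, it means among the compounds named here.

In a functional assay on MIA PaCa-2 cells (Homo sapiens) for inhibition, read by MTT assay, with a stated time of 7 days (a lower number here means a stronger inhibitor, a higher number a weaker inhibitor), compound 1 (`CCCN(CCC)S(=O)(=O)c1ccc(S(=O)(=O)N2CCC[C@@H](C(=O)OCC)C2)cc1`) gives 2300 nM and compound 2 (`CCN(CC)S(=O)(=O)c1ccc(S(=O)(=O)N2CCC[C@@H](C(=O)NC3CN(C(=O)C4CC4)C3)C2)cc1`) gives 2800 nM as half-maximal inhibitory concentrations. These two numbers lie within the scatter of each other, so compound 2 cannot be ranked against compound 1. Compound 3 (`CCN(CC)S(=O)(=O)c1ccc(S(=O)(=O)N2CCC[C@@H](C(=O)NC)C2)cc1`) comes from compound 2 by one change (methyl in place of 1-(cyclopropylcarbonyl)azetidin-3-yl on an amide-type nitrogen), with methyl in place of 1-(cyclopropylcarbonyl)azetidin-3-yl on an amide-type nitrogen. Among the measured compounds shown here, no step between compounds differing in one place has been measured, so its size rests on expectation alone. A modest move in this assay toward a higher number, meaning weaker inhibition, is expected, and a result within the scatter remains possible. The starting point is compound 2 at 2800 nM in these notes. The estimate amounts to a 1.4-fold higher number from compound 2 to compound 3 (0.15 log units; within the scatter) as the expected step. Compound 3 is estimated at 4000 nM with 1300 nM to 12000 nM as its expected range.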

Compound 3, half-maximal inhibitory concentration: 8600 nM
Estimate against measurement, compound 3: 2.2-fold (0.33 log units) below; the range from low to high includes it.
By their numbers in this assay, from the lowest: compounds 1 and 2 (each within the scatter of the next); then compound 3.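

In this assay, among the compounds shown here, the amide-type nitrogen is a position where the substituent matters: methyl in place of 1-(cyclopropylcarbonyl)azetidin-3-yl gives a 3.1-fold higher number from compound 2 to compound 3 (0.49 log units; beyond the scatter) and is the first readable step, with weaker inhibition going with the smaller group in this one pair. This single step does not show which part of the departing group accounts for the difference, whether the three-membered ring, the four-membered ring or the carbonyl. No measurement bearing on the origin of this step is available.

As far as these compounds go, it remains open whether an azetidin-3-yl lacking the cyclopropylcarbonyl, or a cyclopropyl alone on that nitrogen, would match compound 2 in this assay. Simple chains longer than methyl, such as ethyl or n-propyl, also leave open whether the number falls gradually with chain length.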